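The source may hold more compounds than are shown below. What is called first, only, known or untested is meant among the compounds shown, and "the series" means these compounds.

Measured so far:
compound 1, `C=CCCCCOc1ccccc1-c1cnc(OCCC=C)n1C`: 8000 nM
compound 2, `C=CCCCCOc1ccc(OC)cc1-c1cnc(OCCC=C)n1C`: 37000 nM
compound 3, `C=CCCCCOc1ncc(-c2ccccc2OC)n1C`: 5000 nM

These three numbers come from a functional assay on MCF7 cells (Homo sapiens) for inhibition, read by colorimetric assay and MTT assay, with a stated time of 72 h; on this read-out lower numbers stand for stronger inhibition and higher numbers for weaker inhibition. Compound 1 and compound 2 share one core and differ in a single place: methoxy in place of hydrogen on an aromatic carbon. This change gave a 4.6-fold higher number from compound 1 to compound 2 (0.67 log units; beyond the scatter). Compound 3 is built on a different core; the difference between the two cores is not broken down here. Its value stands lowest of the three, but its gap to compound 1 lies within the scatter, so no order between compound 3 and compound 1 can be claimed, while its gap to compound 2 lies beyond the scatter.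

Compound 4, `C=CCCCCOc1ncc(-c2cccc(OC)c2OC)n1C`, has not yet been measured. It differs from compound 3 in one place: methoxy in place of hydrogen on an aromatic carbon. For the measured compounds named here, this is the same kind of change as the one from compound 1 to compound 2, though not the same: in compound 2 the entering group sits para to a (hex-5-en-1-yl)oxy group, whereas in compound 4 it sits ortho to a methoxy group, with both positions meta to a large group.

Going by the values given here, compound 4 is therefore expected to show a weaker number than compound 3, because a 4.6-fold higher number from compound 1 to compound 2 (0.67 log units; beyond the scatter) is the only precedent for this kind of change. The expected step is a 3.0-fold higher number from compound 3 to compound 4 (0.48 log units; beyond the scatter), set somewhat smaller than the earlier one given the changed surroundings. Compound 4 is thus estimated at about 15000 nM, with a likely range from 5000 nM to 50000 nM.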

Compound 4, half-maximal inhibitory concentration: 28000 nM
Estimate against measurement, compound 4: 1.9-fold (0.27 log units) below; measured number inside the range.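

In this assay, the entering methoxy group gave a 5.6-fold higher number from compound 3 to compound 4 (0.75 log units; beyond the scatter), so on the core of compound 3 the change moved the number in the same direction as on the core of compound 1, and the two steps cannot be told apart in size: the same change on two cores in this assay, a 4.6-fold higher number (0.67 log units; beyond the scatter) from compound 1 to compound 2 and a 5.6-fold higher number (0.75 log units; beyond the scatter) from compound 3 to compound 4, 1.2-fold (0.08 log units) apart, within the scatter of two such steps Within this series, then, the change carried over from one core to the other, even though the entering group has different surroundings in the two cases. For the compounds shown here, this rests on only two pairs, however: it does not show that the step would hold on any further core or at another place on the aromatic ring, and it gives no explanation of why the number rises in either case.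

From the compounds shown here alone, it remains open whether a different group in the same place, such as a hydroxyl group, a fluorine atom, an amine or a longer alkoxy chain, would raise the number as methoxy does or would leave it unchanged. Going by these compounds, it is equally open whether the same step would appear with a carboxylic acid at the end of the (hex-5-en-1-yl)oxy chain, or in cells other than those of this assay.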